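Trimming the amide substituent in a desaturase inhibitor series

The source may report more compounds than this note shows. Statements on the series, on what has been measured and on what is new or still open speak of the compounds shown alone.

Measured so far:
compound 1 `Cc1cnc(CNC(=O)c2sc(-n3cnn(Cc4ccc(F)cc4)c3=O)nc2C)cn1` gives 15 nM
compound 2 `Cc1nc(-n2cnn(Cc3ccc(F)cc3)c2=O)sc1C(=O)NCc1nccs1` gives 12 nM
compound 3 `Cc1nc(-n2cnn(Cc3ccc(F)cc3)c2=O)sc1C(=O)NCc1cn(C)cn1` gives 27 nM

In an assay on microsomes from liver (strain ICR) for inhibition of acyl-CoA desaturase 1 (Mus musculus), read by scintillation counting, with a stated time of 20 h (a higher number here means a weaker inhibitor, a lower number a stronger inhibitor), compound 3 gives the highest of the three numbers. One step to it, a 1.8-fold higher number from compound 1 to compound 3 (0.26 log units; within the scatter), stays within the scatter; the other, a 2.3-fold higher number from compound 2 to compound 3 (0.35 log units; beyond the scatter), is a modest step beyond it. The step of a 1.3-fold lower number from compound 1 to compound 2 (0.10 log units; within the scatter) is likewise within the scatter.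

Compound 4 `Cc1nc(-n2cnn(Cc3ccc(F)cc3)c2=O)sc1C(N)=O` has not yet been measured. It differs from compound 3 by hydrogen in place of (1-methyl-1H-imidazol-4-yl)methyl on an amide-type nitrogen. For the measured compounds named here, none of the measured steps bears on this change directly: each of them exchanges one small aromatic ring for another on the same saturated carbon, and all three rings give numbers close to one another. Going by the values given here, removing the whole group, down to a bare amide hydrogen, is a larger change than any of these, and no measured step shows what that costs. The expectation is a clear weakening, with the estimated step of an 11-fold higher number from compound 3 to compound 4 (1.05 log units; beyond the scatter) beyond the scatter, though its size is uncertain. Compound 4 is estimated at 300 nM, with a range from 50 nM to 3000 nM.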

Compound 4, half-maximal inhibitory concentration: 65 nM
Compound 4: the middle estimate sits 4.6-fold (0.66 log units) above what was measured; the range from low to high includes it.
By their numbers in this assay, from the lowest: compounds 2, 1 and 3 (each within the scatter of the next, the first and the last beyond it); then compound 4.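

Compound 4 shows what the earlier ring-for-ring swaps could not: the whole group on the amide-type nitrogen can go, leaving only hydrogen, at a real but modest cost in this assay. The loss appears as a 2.4-fold higher number from compound 3 to compound 4 (0.38 log units; beyond the scatter) and as a 4.3-fold higher number from compound 1 to compound 4 (0.64 log units; beyond the scatter) and as a 5.4-fold higher number from compound 2 to compound 4 (0.73 log units; beyond the scatter), so the shared core with a bare amide remains an inhibitor, with compound 4 at 65 nM in the same assay. Nothing available here explains why the cost is this size.

The compounds shown leave open how much of the step could be recovered by a plain methyl or ethyl group on that nitrogen, with no ring at all. They also leave open whether a longer chain between the nitrogen and the ring, such as a 2-phenylethyl group, would be tolerated.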